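The source may report more compounds than this note shows. Statements on the series, on what has been measured and on what is new or still open speak of the compounds shown alone.

In an ADME assay on LLC-PK1 cells (Sus scrofa) for permeability (a lower number here means that the compound crosses the layer more slowly, a higher number that the compound crosses the layer faster), compound 2 `COc1ccccc1C(=O)NC(=O)Nc1ccc(-c2nccs2)c(C(F)(F)F)c1` gives 12 10^-6 cm/s, the higher of the two numbers obtained so far. Compound 1 `COc1ccccc1C(=O)NC(=O)Nc1ccc(-c2ccccc2)c(C(C)C)c1` gives 1.2 10^-6 cm/s in this assay, and the gap between the two compounds, with compound 2 the higher, lies beyond the scatter. Compound 3 `COc1ccccc1C(=O)NC(=O)Nc1ccc(N2CCCCC2)c(C(F)(F)F)c1` carries piperidin-1-yl in place of 1,3-thiazol-2-yl on an aromatic carbon. Among the compounds with values here, no measured pair shows this particular change, so any expectation for it rests on compound 2 alone. The change is expected to move the number only a little, a 1.5-fold lower number from compound 2 to compound 3 (0.18 log units; within the scatter), not beyond the scatter, with the wider uncertainty allowed for below. Compound 3 is estimated at 8 10^-6 cm/s, within a range of 3 10^-6 cm/s to 20 10^-6 cm/s.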

Compound 3, apparent permeability: < 1 10^-6 cm/s
Compound 3 ended at the assay's limit; the forecaster's own chance of this, stated with the estimate: 5%; middle value at least 8.0-fold (0.90 log units) from the limit.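

Within the data shown here, this is the first reading of a change in one place. With the trifluoromethyl group held constant, piperidin-1-yl in place of 1,3-thiazol-2-yl, on the aromatic carbon para to a large group, gives an at least 12-fold lower number from compound 2 to compound 3 (1.07 log units; beyond the scatter) in this assay, so the number depends strongly on the ring at this position. The value of compound 3, < 1 10^-6 cm/s, is a limit and not a number, so the true size of the step stays unknown: the limit of < 1 10^-6 cm/s in this assay, at which 1 of the 3 values shown sits.

The compounds shown leave open whether the aromatic character of the ring or its particular atoms govern this step. A morpholin-4-yl or a pyridin-2-yl group at the same place would bear on that question.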